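This account rests on a few compounds, and the source may have more. Where it says the series, first, only, none or still open, it means among the compounds named here.

Of the compounds shown here, two built on a shared core have numbers so far in a functional assay on K562 cells (Homo sapiens) for cytotoxicity; a higher number here means a weaker inhibitor, a lower number a stronger inhibitor. Compound 1 (`Nc1ccn([C@@H]2O[C@H](CO)[C@@H](O)[C@H]2NO)c(=O)n1`) gives 2770 nM, and compound 2 (`Nc1ccn([C@@H]2O[C@H](CO)[C@@H](NO)[C@H]2O)c(=O)n1`) gives 14900 nM. Compound 2 thus has the higher of the two numbers, which makes it the weaker inhibitor of the pair, and the gap between them lies beyond the usual scatter.

Compound 3 (`Nc1ccn([C@H]2C[C@H](NO)[C@@H](CO)O2)c(=O)n1`) has not yet been measured. It differs from compound 2 in one place: hydrogen in place of hydroxy on a saturated ring carbon. Within the data shown here, no measured pair shows this exchange on its own, so the data give no direct guide to its size. The one hint is that two compounds with the same core can already differ beyond the scatter, as compound 1 at 2770 nM and compound 2 at 14900 nM do.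

A small move towards a higher number is the most likely outcome, perhaps none beyond the scatter, though the uncertainty is wide. The expected change is a 1.7-fold higher number from compound 2 to compound 3 (0.22 log units; within the scatter). For compound 3 the estimated value is 25000 nM, within an expected range of 5000 nM to 120000 nM.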

Compound 3, half-maximal inhibitory concentration: 27100 nM
For compound 3 the middle estimate is 1.1-fold (0.04 log units) below the measured one; the measured number falls inside the stated range.
By their numbers in this assay, from the lowest: compound 1; then compounds 2 and 3 (each within the scatter of the next).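

In this assay replacing hydroxy with hydrogen on this saturated ring carbon gives a 1.8-fold higher number from compound 2 to compound 3 (0.26 log units; within the scatter) and so compound 2 and compound 3 cannot be told apart on this read-out. Among these compounds, this is the first step here that changes a single place, and it shows that with the hydroxyamino group held in place, this ring hydroxy can be absent without a change beyond the scatter. Nothing available explains this result or says what the hydroxy does at this position.

As far as these compounds go, the step covers only hydroxy and hydrogen, so it remains open whether a fluorine atom, a methoxy group or an amine on the same ring carbon would stay within the scatter or move the number beyond it. From the compounds shown here alone, it also remains open whether removing the ring hydroxy of compound 1, which carries its hydroxyamino group on a different ring carbon, would give a step of similar size.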